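The source may hold more compounds than are shown below. What is called first, only, known or untested is meant among the compounds shown, and "the series" means these compounds.

Measured so far in a physicochemical assay for solubility, read by HPLC, with a stated time of 4 h, at pH 2, tested at 10 mg/mL (on this read-out higher numbers stand for higher solubility and lower numbers for lower solubility), are three compounds:

- compound 1 `Cc1cc(CCC#N)cc(C)c1Oc1cc(Nc2ccc(C#N)cc2)c(N)cc1C(=O)N(C)C` gives 65.1 ug/mL 
- compound 2 `CCNC(=O)c1cc(N)c(Nc2ccc(C#N)cc2)cc1Oc1c(C)cc(CCC#N)cc1C` gives 69.4 ug/mL 
- compound 3 `CC(=O)OCc1cc(N)c(Nc2ccc(C#N)cc2)cc1Oc1c(C)cc(CCC#N)cc1C` gives 2.63 ug/mL 

Compound 3 stands lowest of the three. Both steps leading to it are large and beyond the scatter (a 25-fold lower number from compound 1 to compound 3 (1.39 log units; beyond the scatter)) and (a 26-fold lower number from compound 2 to compound 3 (1.42 log units; beyond the scatter)). In these steps, acetoxymethyl takes the place of dimethylcarbamoyl or ethylcarbamoyl on an aromatic carbon. The exchange between those two carbamoyl groups stays within the scatter (a 1.1-fold higher number from compound 1 to compound 2 (0.03 log units; within the scatter)).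

Compound 4 `COCc1cc(N)c(Nc2ccc(C#N)cc2)cc1Oc1c(C)cc(CCC#N)cc1C` differs from compound 3 in one place (methyl in place of acetyl on an oxygen on a saturated carbon). It has methyl in place of acetyl on an oxygen on a saturated carbon, so acetoxymethyl becomes methoxymethyl. Within the data shown here, no measured step makes this exchange, so the evidence is indirect. Compound 4 does not regain a carbamoyl group, so the large gap seen for compound 1 (a 25-fold lower number from compound 1 to compound 3 (1.39 log units; beyond the scatter)) gives no reason to expect a rise of that size. In this assay no step beyond the scatter is therefore expected, and the estimated step is a 1.5-fold higher number from compound 3 to compound 4 (0.18 log units; within the scatter) at its middle. For compound 4 the estimated value is 4 ug/mL with an expected range from 1.3 ug/mL to 15 ug/mL around that middle.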

Compound 4, solubility: 1.82 ug/mL
The estimate for compound 4 lay 2.2-fold (0.34 log units) above the measured number; low and high end bracket the measured number.
By their numbers in this assay, from the lowest: compounds 4 and 3 (each within the scatter of the next); then compounds 1 and 2 (each within the scatter of the next).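

Changing the group on this oxygen in this assay makes no readable difference (a 1.4-fold lower number from compound 3 to compound 4 (0.16 log units; within the scatter)), even though the exchange replaces three heavy atoms with one and removes a double bond and a hydrogen-bond acceptor. The earlier compounds shown here showed only that acetoxymethyl on this aromatic carbon stood far under the two carbamoyl compounds, and methoxymethyl now shows the same large gap (a 38-fold lower number from compound 2 to compound 4 (1.58 log units; beyond the scatter); a 36-fold lower number from compound 1 to compound 4 (1.55 log units; beyond the scatter)), so in these four compounds the large gaps follow the exchange of a carbamoyl group on the aromatic carbon, and the acetyl-to-methyl change on the oxygen adds no step beyond the scatter. Nothing measured here explains either the large gaps or the absence of a step between compound 3 and compound 4.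

The compounds shown leave open whether a hydroxymethyl group, an aminomethyl group or a carboxylic acid on this aromatic carbon would stay near compound 3 and compound 4 or reach the numbers of compound 1 and compound 2. They also leave open whether a longer chain on the oxygen, such as propyl, would stay within the scatter of compound 4.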